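A few compounds are considered here, and "the series" means these few. Any claim that something is new, unique, unknown or untested is made for them only; others in the source may bear on it.

Compound 1 `CC(C)C[C@@H](N)CN(C(=O)[C@@H]1C[C@H]1c1ccccc1)c1ccc(-c2ccccc2)cc1` gives 1.8 nM in a functional assay for agonist activity at G protein-coupled receptor 88 (Homo sapiens), read by HTRF and cAMP accumulation (a higher number here means that more compound is needed for the effect, a lower number that less compound is needed), and stands highest of the three numbers obtained so far, with compound 2 nearest and compound 3 furthest from it. Compound 2 `CC[C@@H](C)[C@H](N)CN(C(=O)[C@@H]1C[C@H]1c1ccccc1)c1ccc(-c2ccccc2)cc1` gives 1.4 nM, and compound 3 `N[C@H](CN(C(=O)[C@@H]1C[C@H]1c1ccccc1)c1ccc(-c2ccccc2)cc1)C1CCCCC1` gives 0.66 nM. The step of a 1.3-fold lower number from compound 1 to compound 2 (0.11 log units; within the scatter) is within the scatter; the steps of a 2.7-fold lower number from compound 1 to compound 3 (0.44 log units; beyond the scatter) and a 2.1-fold lower number from compound 2 to compound 3 (0.33 log units; beyond the scatter) are modest and beyond it. All three measured changes sit at the same place, the saturated chain carbon bound to the amide-type nitrogen, and vary only the hydrocarbon pattern of the group there.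

Compound 4 `CO[C@H](C)[C@H](N)CN(C(=O)[C@@H]1C[C@H]1c1ccccc1)c1ccc(-c2ccccc2)cc1` differs from compound 1 as follows: 1-amino-2-methoxypropyl in place of 1-amino-3-methylbutyl on a saturated chain carbon bound to an amide-type nitrogen. Among the measured compounds shown here, none of the measured steps brings in a group with a second hydrogen-bond acceptor; the measured steps at this place moved the number little and offer only a loose guide. The change is expected to give a 1.4-fold higher number from compound 1 to compound 4 (0.14 log units; within the scatter), most likely within the scatter or slightly higher. Compound 4 is estimated at 2.5 nM, within a range from 0.9 nM to 8 nM.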

Compound 4, half-maximal effective concentration: 0.68 nM
Compound 4: middle estimate off by 3.7-fold (0.57 log units), on the high side, and the stated range ends above it.
By their numbers in this assay, from the lowest: compounds 3 and 4 (each within the scatter of the next); then compounds 2 and 1 (each within the scatter of the next).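

In this assay, an oxygen in the chain at this place costs nothing: 1-amino-2-methoxypropyl in place of 1-amino-3-methylbutyl gives a 2.6-fold lower number from compound 1 to compound 4 (0.42 log units; beyond the scatter), and 1-methoxyethyl in place of sec-butyl gives a 2.1-fold lower number from compound 2 to compound 4 (0.31 log units; beyond the scatter). The cyclohexyl ring of compound 3 is also not needed for this level, as 1-methoxyethyl in its place gives a 1.0-fold higher number from compound 3 to compound 4 (0.01 log units; within the scatter). Nothing available accounts for the difference between the methoxy compound and its open-chain hydrocarbon counterparts.

Open, from the compounds shown here alone, is whether the oxygen itself matters, which a hydroxyl in place of the methoxy or a longer ethoxy group would test. Also open is how much depends on the configuration of the methoxy-bearing carbon, as only one arrangement of the 1-amino-2-methoxypropyl group is shown here.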